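The source may hold more compounds than are shown below. What is called first, only, known or untested is meant among the compounds shown, and "the series" means these compounds.

Measured so far in a functional assay on MGC-803 cells (Homo sapiens) for inhibition, read by MTT assay, with a stated time of 72 h; on this read-out higher numbers stand for weaker inhibition and lower numbers for stronger inhibition
- compound 1 `Cc1cc(Nc2cc(-c3ccccc3)[nH]n2)n2nc(SCCc3ccccc3)nc2n1` at 5620 nM
- compound 2 `Cc1cc(Nc2cc(-c3ccccc3)[nH]n2)n2nc(SCc3cccc(Br)c3)nc2n1` at 4820 nM

Compound 2 (4820 nM) stands within the scatter of compound 1, so the two values give no order. The change from compound 2 to the unmeasured compound 3 `C#CCSc1nc2nc(C)cc(Nc3cc(-c4ccccc4)[nH]n3)n2n1` is ethynyl in place of 3-bromophenyl on a saturated chain carbon bound to a sulfur. Going by the values given here, only one measured step bears on this (a 1.2-fold lower number from compound 1 to compound 2 (0.07 log units; within the scatter)). It altered the group at the same place and stayed within the scatter, but compound 1 and compound 2 both keep a six-membered aromatic ring in that group. Among the compounds with values here, no measured compound shows what happens without that ring, so the data give no direction for this change. In this assay no step beyond the scatter is expected, and this expectation has thin support, so the range is kept wide. The expected step is small (a 1.0-fold higher number from compound 2 to compound 3 (0.02 log units; within the scatter)). The estimate for compound 3 is 5000 nM with an expected range (1500 nM to 16000 nM).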

Compound 3, half-maximal inhibitory concentration: 13400 nM
Estimate against measurement, compound 3: 2.7-fold (0.43 log units) below; the measured number falls inside the stated range.
By their numbers in this assay, from the lowest: compounds 2 and 1 (each within the scatter of the next); then compound 3.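

In this assay the group on a saturated chain carbon bound to a sulfur proves not to be indifferent to change: ethynyl in place of 3-bromophenyl gives a 2.8-fold higher number from compound 2 to compound 3 (0.44 log units; beyond the scatter) and ethynyl in place of benzyl gives a 2.4-fold higher number from compound 1 to compound 3 (0.38 log units; beyond the scatter) as a matching modest shift toward weaker inhibition. Going by these compounds alone, compound 1 and compound 2, which both keep a six-membered aromatic ring in that group, stand within the scatter of each other, while compound 3, the only member without such a ring, has the highest number of the three and so the weakest inhibition in this set, though this rests on a single ringless example. No measurement on hand gives a reason for this shift.

The change removes the aromatic ring and cuts the heavy atom count in one move, and it also brings in a triple bond, so these three differences cannot be separated with the compounds shown. A plain propyl chain would test the triple bond, while a cyclohexylmethyl group would test whether a ring must be aromatic, and an amine or a carboxylic acid at the end of the chain remains entirely unexplored at this position.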